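Swapping hydroxy for dimethylamino in compound 3

This account rests on a few compounds, and the source may have more. Where it says the series, first, only, none or still open, it means among the compounds named here.

- compound 1 `CCNCC(=O)Nc1cc(OC)ccc1C(=O)c1ccc(OC)c2c1C=CC(C)(C)O2` gives 4270 nM
- compound 2 `CNCC(=O)Nc1cc(OC)ccc1C(=O)c1cc(OC)c(OC)c(OC)c1` gives 690 nM
- compound 3 `C=C(c1cc(OC)c(OC)c(OC)c1)c1ccc(OC)cc1NC(=O)CO` gives 30 nM

In a functional assay on HeLa cells (Homo sapiens) for antiproliferative activity, read by MTT assay, with a stated time of 48 h (on this read-out lower numbers stand for stronger inhibition and higher numbers for weaker inhibition), compound 3 has the lowest of the three numbers, at 30 nM and its gaps to compound 2 (690 nM) and to compound 1 (4270 nM) lie beyond the usual scatter of repeated measurements.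

The next compound is compound 4 `C=C(c1cc(OC)c(OC)c(OC)c1)c1ccc(OC)cc1NC(=O)CN(C)C` which keeps all of compound 3 except one group: dimethylamino stands in place of hydroxy on a saturated chain carbon bound to a carbonyl carbon (dimethylamino in place of hydroxy on a saturated chain carbon bound to a carbonyl carbon).

Among the measured compounds shown here, no measured pair shows this exchange on its own, so any forecast is loose. Compound 2 carries an amino group on such a chain carbon and gives 690 nM in this assay but its core differs from that of compound 3, which makes it only a weak hint. A moderate weakening is therefore expected, with an estimated 3.3-fold higher number from compound 3 to compound 4 (0.52 log units; beyond the scatter) towards a higher number in this assay and beyond the scatter. The estimated value for compound 4 is 100 nM with 20 nM to 500 nM as the expected range.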

Compound 4, half-maximal inhibitory concentration: 370 nM
The estimate for compound 4 lay 3.7-fold (0.57 log units) below the measured number; low and high end bracket the measured number.
By their numbers in this assay, from the lowest: compound 3; then compounds 4 and 2 (each within the scatter of the next); then compound 1.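

In this assay, among the compounds shown here, dimethylamino in place of hydroxy on a saturated chain carbon bound to a carbonyl carbon gives a 12-fold higher number from compound 3 to compound 4 (1.09 log units; beyond the scatter) and thus provides the first reading of a single change, as the earlier compounds differ from one another in more than one place. This large step, beyond the usual scatter, shows that the group on this chain carbon strongly affects the result even when the rest of the molecule stays the same. The exchange replaces one heavy atom with three and removes a hydrogen-bond donor, but no measurement at hand explains the rise in the number.

The compounds shown leave open which of those differences matters, and an amino group, a methoxy group or a longer chain on the same carbon would help to separate them. On these data alone, it also remains open whether this exchange would have a similar effect on the core of compound 1 or compound 2, as neither carries hydroxy at this place.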